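This account rests on a few compounds, and the source may have more. Where it says the series, first, only, none or still open, it means among the compounds named here.

Working notes on the series. Within the data shown here, compound 2 `CC1=C(C(=O)Nc2ccc([N+](=O)[O-])cc2)C(c2cccc([N+](=O)[O-])c2)N=C(SCc2ccccc2Cl)N1` gives the lowest of the two numbers so far: in a functional assay on the whole organism (artery, strain albino) with Rattus norvegicus as the target, with a stated time of 240 min, at a dose of 10 mg/kg by the oral route (a lower number here means less inhibition, a higher number more inhibition at the dose given (going by the name of the read-out)), compound 2 shows 12.8%. Among the measured compounds shown here, its nearest neighbour is compound 1 `CC1=C(C(=O)Nc2ccc([N+](=O)[O-])cc2)C(c2ccc(Br)cc2)N=C(SCc2ccccc2Cl)N1`, which in this assay gives 15.4%, and the single step recorded, a number 2.6 percentage points lower from compound 1 to compound 2 (within the scatter), lies within the scatter, so the two compounds cannot be ordered.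

Compound 3 `CC1=C(C(=O)Nc2ccc([N+](=O)[O-])cc2)C(c2cccc([N+](=O)[O-])c2)N=C(SCc2ccc(F)cc2)N1` has not yet been measured. It differs from compound 2 at another place altogether: 4-fluorophenyl in place of 2-chlorophenyl on a saturated chain carbon bound to a sulfur. For the measured compounds named here, the one measured step concerns the group on the saturated ring carbon, not the group on the saturated chain carbon bound to a sulfur, so no step bears directly on this change. Going by the values given here, the only guidance is that the single substitution tried so far moved the read-out by less than the scatter. On that basis the step from compound 2 to compound 3 is expected to be small, a number 0.2 percentage points higher from compound 2 to compound 3 (within the scatter), with no direction beyond the scatter claimed. Compound 3 is therefore estimated at 13% in this assay, within 3% to 25%.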

Compound 3, a percentage reported as inhibition, in the whole organism at one dose (the size of the read-out at that dose, not a potency): 22.6%
The estimate for compound 3 lay 9.6 percentage points below the measured number; measured number inside the range.
By their numbers in this assay, from the lowest: compounds 2, 1 and 3 (each within the scatter of the next).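

In this assay, the exchange of 2-chlorophenyl for 4-fluorophenyl on the saturated chain carbon bound to a sulfur gives the first step read at this place, a number 9.8 percentage points higher from compound 2 to compound 3 (within the scatter). The step recorded at the saturated ring carbon, a number 2.6 percentage points lower from compound 1 to compound 2 (within the scatter), also lies within the scatter, so neither place can yet be called the more responsive one, and the change at the chain carbon gives no ordering of compound 2 and compound 3. No measurement at hand accounts for the read-out at this place.

The two groups differ both in the halogen and in where it stands on the phenyl ring, so these two features cannot be separated here; 4-chlorophenyl or 2-fluorophenyl at the same place would separate them. On these data alone, whether an aromatic ring is needed on this chain carbon at all also remains open, and a plain phenyl, a cyclohexyl or a chain ending in an amine or a carboxylic acid would address that question.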